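The compounds below may be only part of what the source reports. "The series", "measured", "known", "first", "only" and "open" are said of these compounds alone.

Series notes. Compound 1 `Cc1nn2c(-c3ccccc3)nnc2cc1Cc1ccccc1` and compound 2 `Cc1nn2c(N)nnc2cc1Cc1ccccc1` share one core and are separated by a single change, amino in place of phenyl on an aromatic carbon. In a functional assay on the whole organism with Mus musculus as the target, in the maximal electroshock model (on this read-out lower numbers stand for an effect already at smaller amounts and higher numbers for an effect only at larger amounts of compound), compound 1 gives 108 mg/kg. Compound 2 gives 22 mg/kg in this assay, and the step of a 4.9-fold lower number from compound 1 to compound 2 (0.69 log units; beyond the scatter) is the only one measured so far. Compound 2 therefore stands at the lowest of the two numbers seen, its nearest neighbour being compound 1.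

The next compound, compound 3 `Cc1nn2c(NC(=O)c3ccccc3)nnc2cc1Cc1ccccc1`, is reached from compound 2 by benzoyl in place of hydrogen on a nitrogen on an aromatic ring. Among the compounds with values here, no measured step corresponds to this change directly. Within the data shown here, the one step that bears on it is a 4.9-fold lower number from compound 1 to compound 2 (0.69 log units; beyond the scatter), which shows that the compound carrying a free amino gives a lower number than the compound carrying a phenyl at the same place; compound 3 brings a phenyl-containing group back onto that amino. The expected step is accordingly toward a higher number, estimated at a 2.0-fold higher number from compound 2 to compound 3 (0.31 log units; beyond the scatter), smaller than the measured step and possibly not beyond the scatter. For compound 3 the estimated value in this assay is 45 mg/kg, with a range from 15 mg/kg to 140 mg/kg.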

Compound 3, dose for half-maximal effect: 35 mg/kg
Beside the measured number, compound 3's estimate is 1.3-fold (0.11 log units) above it; the measured number falls inside the stated range.
By their numbers in this assay, from the lowest: compounds 2 and 3 (each within the scatter of the next); then compound 1.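

In this assay, putting benzoyl on the nitrogen of the free amino group gives a 1.6-fold higher number from compound 2 to compound 3 (0.20 log units; within the scatter), so a group of this size can stand on that nitrogen without a step that can be told from repeat measurements. The hydrogen replaced there is thus not needed to keep the number in the range of compound 2, and the nitrogen now carries a carbonyl and a six-membered aromatic ring instead. A phenyl ring within the group at this place also does not by itself bring the value printed for compound 1, 108 mg/kg: compound 3, which also carries such a ring, stands at 35 mg/kg. Nothing available explains why the benzoyl group leaves the number within the scatter of the free amino compound.

The compounds shown leave open how an acetyl group, a longer chain such as phenylacetyl or a simple methyl on the same nitrogen would read in this assay. They also leave open whether the aromatic ring of the benzoyl group matters at all, or whether the carbonyl alone would give a similar number.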